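A larger group on the oxygen of compound 1

The source may report more compounds than this note shows. Statements on the series, on what has been measured and on what is new or still open speak of the compounds shown alone.

In a functional assay on A549 cells (Homo sapiens) for inhibition, read by sulforhodamine B assay, with a stated time of 48 h, tested at 50 uM (on this read-out higher numbers stand for more inhibition of growth at the one concentration tested and lower numbers for less inhibition of growth), compound 1 `COc1ccc([C@@H]2CC(=O)c3cc(CC=C(C)C)c(OC)cc3O2)cc1` gives 45% and compound 2 `COc1cc2c(cc1CC=C(C)C)[C@H](O)C[C@@H](c1ccc(O)cc1)O2` gives 48% so the two stand level within the usual scatter. Compound 3 `COc1cc2c(cc1CC=C(C)C)C(=O)C[C@@H](c1ccc(Oc3ccc(Br)cc3)cc1)O2` differs from compound 1 by 4-bromophenyl in place of methyl on an oxygen on an aromatic ring with 4-bromophenyl in place of methyl on an oxygen on an aromatic ring. Going by the values given here, no measured pair shows a change of this kind, so any expectation here is loose. The expected step of a number 13 percentage points higher from compound 1 to compound 3 (beyond the scatter) is a modest rise in growth inhibition. Compound 3 is estimated at 58% with an expected range from 35% to 85% on this measure.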

Compound 3, percent growth inhibition at one concentration: 72%
Compound 3: middle estimate off by 14 percentage points, on the low side, and the stated range covers the measured number.
By their numbers in this assay, from the lowest: compounds 1 and 2 (each within the scatter of the next); then compound 3.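

Putting 4-bromophenyl in place of methyl on this oxygen goes with a number 27 percentage points higher from compound 1 to compound 3 (beyond the scatter) in this assay. This position therefore accepts a whole extra aromatic ring with no loss of growth inhibition, something that compound 1 and compound 2 alone could not show. Nothing measured here gives a reason for the rise.

From the compounds shown here alone, whether the rise belongs to the bromine or to the added ring itself stays open. Also open, going by these compounds, is how a plain phenyl, a benzyl group or a longer alkyl chain on the same oxygen would compare.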